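Isopropyl Amide Swapped for a Methoxycarbonyl Side Chain

The compounds below may be only part of what the source reports. "The series", "measured", "known", "first", "only" and "open" are said of these compounds alone.

Compound 1 `CC(C)NC(=O)c1ccc(NCc2cncn2Cc2ccc(C#N)cc2)cc1-c1ccccc1` is one of three measured members of a series sharing the same core. In a functional assay on NIH3T3 cells (Mus musculus) (a higher number here means that more compound is needed for the effect, a lower number that less compound is needed), compound 1 returns only a limit, > 10 uM. Compound 2 `CSCC[C@H](NC(=O)c1ccc(NCc2cncn2Cc2cccc(Cl)c2)cc1-c1ccccc1)C(=O)O` also stops at a limit in this assay, > 10 uM. Compound 3 `COC(=O)[C@H](CCSC)NC(=O)c1ccc(CN(Cc2c[nH]cn2)Cc2c[nH]cn2)cc1-c1ccccc1C` likewise gives a limit in this assay, > 10 uM. All three therefore sit at the limit of > 10 uM in this assay, at which 3 of the 3 values shown sit, so no number separates them, and nothing here marks any of them as stronger or weaker than the others.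

Compound 4 `COC(=O)[C@H](CCSC)NC(=O)c1ccc(NCc2cncn2Cc2ccc(C#N)cc2)cc1-c1ccccc1` has not yet been measured. It differs from compound 1 in one place (1-(methoxycarbonyl)-3-(methylsulfanyl)propyl in place of isopropyl on an amide-type nitrogen). The change sits on an amide-type nitrogen whose other neighbour is a carbonyl carbon. Compound 2 and compound 3 already carry comparable groups on such a nitrogen and remain at the limit.

Since all three known values are limits, nothing guides the size of the expected step that the limit leaves unreadable from compound 1 to compound 4, which is expected to be small or absent. Compound 4 is estimated at 15 uM, in a range from 4 uM to 60 uM, most likely again reported as a limit.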

Compound 4, concentration for half-maximal effect: > 10 uM
Compound 4 was reported as a limit; the forecaster's own chance of this, stated with the estimate: 70%; the middle value is on the limit's open side.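

In this assay compound 4 gives > 10 uM, which is a limit and not a number. Within the data shown here, compound 1 also stands only at a limit, so no step between compound 1 and compound 4 can be read: the limit of > 10 uM in this assay, at which 4 of the 4 values shown sit. The compounds shown leave open what concentration any of them needs for the effect, and whether the change on the amide-type nitrogen alters it at all.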